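A few compounds are considered here, and "the series" means these few. Any claim that something is new, unique, unknown or untested is made for them only; others in the source may bear on it.

Measured so far:
compound 1 `N[C@@H](COP(=O)(O)OCCCOC(=O)CCc1ccccc1OCc1cccc(OC2CCCCC2)c1)C(=O)O` gives 0.11 in an assay on cells for activation of probable G-protein coupled receptor 34 (Mus musculus), with a stated time of 1 h; on this read-out lower numbers stand for smaller maximal responses and higher numbers for larger maximal responses
compound 2 `N[C@@H](COP(=O)(O)OCCCOC(=O)CCc1ccccc1OCc1cccc(Oc2ccccc2Cl)c1)C(=O)O` gives 0.069 in this assay
compound 3 `N#Cc1ccc(Oc2cccc(COc3ccccc3CCC(=O)OCCCOP(=O)(O)OC[C@H](N)C(=O)O)c2)cc1` gives 0.041 in this assay

Compound 3 holds the lowest of the three numbers, yet its separation from the others is small: a number 0.028 lower from compound 2 to compound 3 (within the scatter) and a number 0.069 lower from compound 1 to compound 3 (within the scatter), both within the scatter. Compound 4 `CC(C)(C)c1ccc(Oc2cccc(COc3ccccc3CCC(=O)OCCCOP(=O)(O)OC[C@H](N)C(=O)O)c2)cc1` differs from compound 3 in one place: tert-butyl in place of cyano on an aromatic carbon. All three measured steps also swap the group carried on the oxygen of that aromatic ring, and none of them moved the response beyond the scatter: a number 0.041 lower from compound 1 to compound 2 (within the scatter), a number 0.069 lower from compound 1 to compound 3 (within the scatter) and a number 0.028 lower from compound 2 to compound 3 (within the scatter). For the measured compounds named here, no measured step puts a tert-butyl in place of a cyano, so the closest guide is that changes at this position have so far left the response essentially flat. The step is therefore expected to be small, a number 0.019 higher from compound 3 to compound 4 (within the scatter), with no direction claimed beyond the scatter. The estimate for compound 4 in this assay is 0.06, expected to fall between 0.02 and 0.14.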

Compound 4, intrinsic activity: the largest response reached, as a fraction of the reference agonist's: 0.079
The estimate for compound 4 lay 0.019 below the measured number; measured number inside the range.
By their numbers in this assay, from the lowest: compounds 3, 2, 4 and 1 (each within the scatter of the next).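

In this assay, exchanging cyano for tert-butyl on the aromatic carbon, which takes the group from 2 heavy atoms to 4 and removes its hydrogen-bond acceptor, gives a number 0.038 higher from compound 3 to compound 4 (within the scatter), so this change on the ring shows no measurable effect on the maximal response. The whole group on the oxygen tells the same story, with a number 0.010 higher from compound 2 to compound 4 (within the scatter) and a number 0.031 lower from compound 1 to compound 4 (within the scatter), so 4-(tert-butyl)phenyl cannot be told apart from 2-chlorophenyl or cyclohexyl here. No measurement is available that could explain this flat result.

On these data alone, whether an amine or a carboxylic acid on that same aromatic carbon would give a response clearly apart from these four compounds remains open. A longer chain on the oxygen, in place of these rings, is equally untested by the compounds shown.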